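A few compounds are considered here, and "the series" means these few. Any claim that something is new, unique, unknown or untested is made for them only; others in the source may bear on it.

Compound 1 `CCOC(=O)c1cccc(-c2cnc(C(=O)CCc3ccc(-c4ccccc4)cc3)o2)n1` gives 3 nM in an assay for inhibition of Fatty-acid amide hydrolase 1 (Rattus norvegicus); on this read-out lower numbers stand for stronger inhibition and higher numbers for weaker inhibition.
Compound 2 `O=C(O)c1cc(-c2cnc(C(=O)CCc3ccc(-c4ccccc4)cc3)o2)ccn1` gives 50 nM in this assay.
Compound 3 `NC(=O)c1cccc(-c2cnc(C(=O)CCc3ccc(-c4ccccc4)cc3)o2)n1` gives 1.2 nM in this assay.

Compound 3 stands lowest of the three numbers, and both steps leading to it lie beyond the scatter: a 2.5-fold lower number from compound 1 to compound 3 (0.40 log units; beyond the scatter) is the nearer one, a 42-fold lower number from compound 2 to compound 3 (1.62 log units; beyond the scatter) the far larger one. Compound 4 `NC(=O)c1ccc(-c2cnc(C(=O)CCc3ccc(-c4ccccc4)cc3)o2)nc1` has not been measured. Among the measured compounds shown here, its single difference from compound 3 is 5-carbamoylpyridin-2-yl in place of 6-carbamoylpyridin-2-yl on an aromatic carbon. Neither measured step isolates a move of this kind. The step from compound 1 to compound 3 alters only the group on the carbonyl carbon, not where that group sits on the ring. The step from compound 2 to compound 3 does exchange the whole pyridinyl group, but it swaps carboxy for carbamoyl at the same time, so how much of that large step comes from the position alone cannot be read off. For the measured compounds named here, what remains is that the one change touching the ring arrangement coincided with the largest step seen here, so a noticeable shift is plausible, most likely toward a higher number, while a result within the scatter cannot be ruled out. Compound 4 is therefore expected at 10 nM, with a range from 2 nM to 60 nM, which amounts to an expected step of an 8.3-fold higher number from compound 3 to compound 4 (0.92 log units; beyond the scatter).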

Compound 4, inhibition constant: 1.3 nM
Compound 4: the middle estimate sits 7.7-fold (0.89 log units) above what was measured; measured number below the stated range.
By their numbers in this assay, from the lowest: compounds 3 and 4 (each within the scatter of the next); then compound 1; then compound 2.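

In this assay, among the compounds shown here, 5-carbamoylpyridin-2-yl in place of 6-carbamoylpyridin-2-yl, on the aromatic carbon next to the ring oxygen, gives a 1.1-fold higher number from compound 3 to compound 4 (0.03 log units; within the scatter) and so makes no readable difference, which is the first view of this exchange on its own. The gap to the carboxylic acid also holds with the new group, at a 38-fold lower number from compound 2 to compound 4 (1.59 log units; beyond the scatter) alongside a 42-fold lower number from compound 2 to compound 3 (1.62 log units; beyond the scatter) for the earlier amide, so among these compounds both carbamoyl arrangements stand well clear of compound 2. No measurement shown here explains why the two carbamoyl arrangements read alike.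

Compound 2 still differs from compound 3 and compound 4 in both the carboxy group and the pyridinyl arrangement, so the share of its large step that belongs to the acid itself stays unresolved. A carboxylic acid or a nitrile in place of the carbamoyl group on the 5-carbamoylpyridin-2-yl ring would be needed to show whether this tolerance of arrangement extends beyond the amide.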